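Exchanging the methoxyphenyl of a urea for chlorophenyl

A few compounds are considered here, and "the series" means these few. Any claim that something is new, unique, unknown or untested is made for them only; others in the source may bear on it.

Compound 1 `COc1cccc(NC(=O)NC2CC(C)(C)Oc3ccc(F)cc32)c1`: in a functional assay (aorta) with Rattus norvegicus as the target (on this read-out lower numbers stand for an effect already at smaller amounts and higher numbers for an effect only at larger amounts of compound), compound 1 gives only a limit, > 10000 nM.
Compound 2 `COc1ccc(NC(=O)NC2CC(C)(C)Oc3ccc(F)cc32)cc1`: in this assay compound 2 gives 15500 nM.

Compound 2 stands on the only number shown in this assay. The other value, that of compound 1, is a limit, marked by the limit of > 10000 nM in this assay, at which 1 of the 2 values shown sits. For that reason the step that the limit leaves unreadable from compound 1 to compound 2 cannot be read in size or direction.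

Compound 3 `CC1(C)CC(NC(=O)Nc2ccccc2Cl)c2cc(F)ccc2O1` differs from compound 2 by 2-chlorophenyl in place of 4-methoxyphenyl on an amide-type nitrogen. Among the measured compounds shown here, the only measured step, a step that the limit leaves unreadable from compound 1 to compound 2, moves the methoxy group on the ring and leaves no readable number; no measured step introduces a chlorine or removes the methoxy group, so nothing in the data sets a direction for this exchange. The expectation is therefore that the step of a 1.3-fold lower number from compound 2 to compound 3 (0.11 log units; within the scatter) stays within the scatter, with a wide range and a real chance that only a limit is returned.

Compound 3 is expected at 12000 nM in this assay. For compound 3 the estimate spans 3000 nM to 40000 nM.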

Compound 3, half-maximal effective concentration: > 30000 nM
Compound 3 gave a limit, no number (the forecaster's own chance of this, stated with the estimate: 50%); middle value at least 2.5-fold (0.39 log units) from the limit.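

Among the compounds shown here, replacing 4-methoxyphenyl with 2-chlorophenyl on an amide-type nitrogen gives an at least 1.9-fold higher number from compound 2 to compound 3 (0.28 log units; that floor lies within the scatter), the first step at this position with a readable direction. In this assay, the exchange therefore brings no move toward lower numbers, although its floor alone does not establish a real loss. The steps that start at compound 1 cannot be read, and compound 2 remains the only compound with a number: the limit of > 10000 nM in this assay, at which 1 of the 3 values shown sits.

The compounds shown leave open whether the result for compound 3 follows from the chlorine or from where it sits on the ring, as 2-chlorophenyl is the only chlorophenyl group here. Going by these compounds, how 4-chlorophenyl, or a phenyl group carrying a dimethylamino group or a carboxylic acid, would read in this assay also remains open, as does whether any group at this position can give a number clearly lower than that of compound 2.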